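A few compounds are considered here, and "the series" means these few. Any claim that something is new, unique, unknown or untested is made for them only; others in the source may bear on it.

Among the measured compounds shown here, compound 2, with structure `O=C(CC1c2ccccc2N=C(SCCCCCN2CCCC2)N1c1ccc(-c2ccc(F)cc2)cc1)NCc1ccc(F)cc1`, is one of three compounds measured in an assay on cells for inhibition of Voltage-dependent T-type calcium channel subunit alpha-1I (Homo sapiens), read by patch clamp, tested at 10 uM; a lower number here means less inhibition, a higher number more inhibition at the concentration tested (going by the name of the read-out). Compound 2 gives 35.1%, the lowest of the three numbers. Compound 1, with structure `O=C(CC1c2ccccc2N=C(SCCCCCN2CCCC2)N1c1ccc(-c2ccccc2)cc1)NCc1ccc(F)cc1`, gives 55.9%, and compound 3, with structure `O=C(CC1c2ccccc2N=C(SCCCCCN2CCCC2)N1c1ccc(-c2ccc(F)cc2)cc1)NCc1ccccc1`, gives 68.2%; both values lie beyond the scatter above that of compound 2. The two measured steps are both exchanges of fluoro and hydrogen on an aromatic carbon: the step of a number 20.8 percentage points lower from compound 1 to compound 2 (beyond the scatter) and the step of a number 33.1 percentage points higher from compound 2 to compound 3 (beyond the scatter).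

Compound 4, with structure `O=C(CC1c2ccccc2N=C(SCCCCCN2CCCC2)N1c1ccccc1)NCc1ccc(F)cc1`, has not yet been measured. Its difference from compound 2 is hydrogen in place of 4-fluorophenyl on an aromatic carbon. Neither measured step removes a whole aryl group, so neither bears directly on this change; the step of a number 20.8 percentage points lower from compound 1 to compound 2 (beyond the scatter) touches the same group that now leaves, but only by changing a single substituent on it. The measured steps show that this series moves by modest to large amounts on small changes, so a step beyond the scatter in either direction is possible, and the direction cannot be read from the data. Compound 4 is therefore expected to give about 40%, in the range 15% to 65%, which is an estimated step of a number 4.9 percentage points higher from compound 2 to compound 4 (within the scatter).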

Compound 4, a percentage reported as inhibition, at one concentration (the size of the read-out at that concentration, not a potency): 22.1%
Compound 4: middle estimate off by 17.9 percentage points, on the high side; the measured number falls inside the stated range.
By their numbers in this assay, from the lowest: compound 4; then compound 2; then compound 1; then compound 3.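

In this assay, among the compounds shown here, the earlier compounds showed only that a fluoro on the outer phenyl ring shifts the number, whereas these results concern the whole aryl group on this aromatic carbon, which lies para to a large group. Exchanging 4-fluorophenyl for hydrogen is the step of a number 13 percentage points lower from compound 2 to compound 4 (beyond the scatter) and exchanging phenyl for hydrogen is the step of a number 33.8 percentage points lower from compound 1 to compound 4 (beyond the scatter), so in both pairs the number falls beyond the scatter, whether or not the departing ring carries fluoro. Among these pairs, then, an aryl group at this place goes with more inhibition at the tested concentration than hydrogen does, and the fluoro on that ring does not decide the direction of the change, though nothing available here explains the fall.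

The compounds shown leave open how much of the aryl group is needed, since nothing lies between hydrogen and a full phenyl ring at this carbon, such as a methyl, a methoxy or a chlorine. They also leave open whether a pyridyl or cyclohexyl ring could stand in for the phenyl ring, and whether the benzyl fluoro shifts the number in the same way once the aryl group is gone.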